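Methoxy for trifluoromethyl on the aryl of compound 3

The compounds below may be only part of what the source reports. "The series", "measured", "known", "first", "only" and "open" are said of these compounds alone.

Compound 3 `Nc1nc(-c2cccc(C(F)(F)F)c2)nc2sc(Cc3ccccc3)cc12` reaches only a limit in a functional assay on CHO-K1 cells for antagonist activity at adenosine receptor A1 (Homo sapiens), read by a beta-galactosidase reporter and cAMP accumulation, with stated times of 15 min and 6 h (on this read-out lower numbers stand for stronger inhibition and higher numbers for weaker inhibition), and that limit is > 1000 nM. Within the series, compound 2 `Nc1nc(-c2cccc(F)c2)nc2sc(Cc3ccccc3)cc12` gives 123 nM in this assay, and compound 1 `Nc1nc(-c2ccc(C(F)F)o2)nc2sc(Cc3ccccc3)cc12` gives 3000 nM. The step of a 24-fold lower number from compound 1 to compound 2 (1.39 log units; beyond the scatter) is the largest drop measured, while the step of an at least 8.1-fold higher number from compound 2 to compound 3 (0.91 log units; beyond the scatter) runs the other way and ends at the limit described by the limit of > 1000 nM in this assay, at which 1 of the 3 values shown sits. Compound 4 `COc1cccc(-c2nc(N)c3cc(Cc4ccccc4)sc3n2)c1` differs from compound 3 by methoxy in place of trifluoromethyl on an aromatic carbon. Among the measured compounds shown here, the only measured step that bears on this position is the one from fluoro to trifluoromethyl, which cost at least a modest amount; methoxy is nearer to fluoro than to trifluoromethyl in the count of heavy atoms, so a fall in number is expected, though not necessarily back to the level of compound 2. The estimated step is an at least 2.5-fold lower number from compound 3 to compound 4 (0.39 log units; beyond the scatter). Compound 4 is expected to give about 400 nM in this assay, with a likely range from 100 nM to 2000 nM.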

Compound 4, inhibition constant: 266 nM
Compound 4: the middle estimate sits 1.5-fold (0.18 log units) above what was measured; the range from low to high includes it.
By their numbers in this assay, from the lowest: compound 2; then compound 4; then compound 1.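

In this assay, methoxy on this aromatic carbon gives an at least 3.7-fold lower number from compound 3 to compound 4 (0.57 log units; beyond the scatter), a size that remains only a bound. Compound 3 stands at a limit of the assay, not at a number: the limit of > 1000 nM in this assay, at which 1 of the 4 values shown sits. Methoxy does not reach the level of fluoro, with a 2.2-fold higher number from compound 2 to compound 4 (0.33 log units; beyond the scatter), yet a second substituted phenyl also clearly outdoes the 5-(difluoromethyl)furan-2-yl group, with an 11-fold lower number from compound 1 to compound 4 (1.05 log units; beyond the scatter).

As far as these compounds go, how an amine, a hydroxyl or a carboxylic acid would stand on this same aromatic carbon remains open, since the comparison so far covers fluoro, methoxy and trifluoromethyl alone. Also open, from the compounds shown here alone, is whether the order of these three groups would hold on other carbons of the ring or with changes elsewhere on the shared core.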